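The source may report more compounds than this note shows. Statements on the series, on what has been measured and on what is new or still open speak of the compounds shown alone.

Of the compounds shown here, two built on one shared core have been tested in a functional assay on HL-60 cells (Homo sapiens) for antiproliferative activity, read by MTT assay, with a stated time of 24 h; a higher number here means a weaker inhibitor, a lower number a stronger inhibitor. Compound 1 `CCCCc1oc2ccccc2c1C(=O)c1ccc(OCC(N)=O)cc1` gives > 50000 nM, which is a limit of the assay and not a number. Compound 2 `CCCCc1oc2ccccc2c1C(=O)c1ccc(OCC(=O)N2CCCC2)cc1` gives > 50000 nM, again only a limit. Among the measured compounds shown here, compound 2 therefore has no exact place on the scale, and the one other value available is a limit too: the data show (the limit of > 50000 nM in this assay, at which 2 of the 2 values shown sit).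

Compound 3 `CCCCc1oc2ccccc2c1C(=O)c1ccc(OCC(=O)N2CCCCC2)cc1` has piperidin-1-yl in place of pyrrolidin-1-yl on a carbonyl carbon, so the ring grows while the rest of the molecule stays the same: piperidin-1-yl in place of pyrrolidin-1-yl on a carbonyl carbon. For the measured compounds named here, only one measured step bears on this change, and it replaces amino with pyrrolidin-1-yl at the same carbonyl carbon. That step is a step that the two limits leave unreadable from compound 1 to compound 2, so it supplies no size to carry forward. No shift beyond the scatter is therefore expected in this assay, and no direction can be favoured. The expected step is a step that the limit leaves unreadable from compound 2 to compound 3. For compound 3 the estimated value is 60000 nM, with an expected range from 25000 nM to 150000 nM, and the assay may well report only a limit again.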

Compound 3, half-maximal inhibitory concentration: > 50000 nM
Compound 3 was reported as a limit (the forecaster's own chance of this, stated with the estimate: 85%); the middle value does not contradict the limit.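

In this assay compound 3 gives > 50000 nM, which is a limit of the assay and not a number. Among the compounds shown here, no step among compound 1, compound 2 and compound 3 can be read: the limit of > 50000 nM in this assay, at which 3 of the 3 values shown sit. The compounds shown leave open where each one lies beyond that limit, and whether the group on the carbonyl carbon matters in this assay.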